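From Isopropylsulfanyl to Butoxy: A Cell Toxicity Question

A few compounds are considered here, and "the series" means these few. Any claim that something is new, unique, unknown or untested is made for them only; others in the source may bear on it.

Three compounds share one core and differ only in a single side group: compound 1 `CC(C)Nc1nc(N)nc2c1ncn2/C=C1/CC1(CO)CO`, compound 2 `CC(C)Sc1nc(N)nc2c1ncn2/C=C1/CC1(CO)CO` and compound 3 `CCCCOc1nc(N)nc2c1ncn2/C=C1/CC1(CO)CO`. The test of interest here is an ADME assay on MOLT-3 cells (Homo sapiens) for cytotoxicity, with a stated time of 7 days; on this read-out higher numbers stand for lower toxicity in this test and lower numbers for higher toxicity in this test. In this test, compound 1 has no usable result: "not determined" (no result reported). In this assay compound 2 gives > 20000 nM, which is a limit of the assay and not a number. No toxic concentration can therefore be read for compound 2, and no measured comparison exists between any two of these compounds.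

Compound 3 carries butoxy in place of isopropylsulfanyl on an aromatic carbon. With only the limit of compound 2 at > 20000 nM to go on, no clear change in toxicity is expected. The estimated step of a number no higher from compound 2 to compound 3 (the limit leaves the size open) is expected to stay within the usual scatter, with no direction favoured. Compound 3 is expected at about 20000 nM, with an estimated range from 6000 nM to 60000 nM. The test may well again return only a limit.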

Compound 3, half-maximal cytotoxic concentration: > 20000 nM
Compound 3 ended at the assay's limit (the forecaster's own chance of this, stated with the estimate: 60%); the middle value sits exactly at the limit.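

No step from compound 2 to compound 3 can be read, because both results are limits of the assay and not numbers: the limit of > 20000 nM in this assay, at which 2 of the 3 values shown sit.

The compounds shown leave open at what concentration compound 2 and compound 3 would become toxic to these cells, and whether butoxy in place of isopropylsulfanyl changes that concentration at all.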